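This account rests on a few compounds, and the source may have more. Where it says the series, first, only, none or still open, it means among the compounds named here.

Compound 1, with the structure `COc1ccc(/C(=N/O)c2cccc3ccccc23)c(OC)c1OC`, is one of three compounds that have been tested in a functional assay on MDA-MB-231 cells (Homo sapiens) for inhibition, read by sulforhodamine B assay, with a stated time of 48 h; on this read-out lower numbers stand for stronger inhibition and higher numbers for weaker inhibition. In this assay compound 1 gives 2500 nM. Compound 2, with the structure `COc1ccc(C(c2ccc(OC(C)CN(C)C)cc2)c2cccc3ccccc23)c(OC)c1OC`, gives 4340 nM in this assay, and the two numbers sit within the scatter of each other, so neither can be called the stronger. Compound 3, with the structure `C=CCC(O)(c1ccc(OC)c(OC)c1OC)c1cccc2ccccc12`, reaches only a limit in this assay, > 20000 nM; the record notes (the limit of > 20000 nM in this assay, at which 1 of the 3 values shown sits). Compound 1 therefore holds the lowest of the two actual numbers, with compound 2 close beside it.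

Compound 4, with the structure `COc1ccc(/C(=N/OCC(=O)O)c2cccc3ccccc23)c(OC)c1OC`, has not yet been measured in this assay. It differs from compound 1 in a single place: carboxymethyl in place of hydrogen on an oxygen, so that the hydroxy of compound 1 becomes a carboxymethoxy. Among the measured compounds shown here, no pair of measured compounds here differs in only one place, so no measured step can serve as a guide for the size of this change. The expectation is nevertheless for a modest loss, a step of a 2.4-fold higher number from compound 1 to compound 4 (0.38 log units; beyond the scatter) in this assay. On that basis compound 4 is estimated to give 6000 nM in this assay, with a likely range from 2000 nM to 20000 nM.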

Compound 4, half-maximal inhibitory concentration: > 20000 nM
Compound 4: only a limit was reported; the forecaster's own chance of this, stated with the estimate: 20%; at least 3.3-fold (0.52 log units) between middle value and limit.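

Among the compounds shown here, the earlier compounds offered no pair differing in one place, so this is the first measured look at what a change on this oxygen, the one bonded to the double-bonded nitrogen, can do. In this assay, turning the hydroxy into a carboxymethoxy gives an at least 8.0-fold higher number from compound 1 to compound 4 (0.90 log units; beyond the scatter), so the position does not accept this addition without a clear loss of inhibition of these cells, and the step lies beyond the usual scatter. For compound 4 the reading of > 20000 nM is a limit and not a number, so the step gives only a floor for the loss and its full size stays unknown: the limit of > 20000 nM in this assay, at which 2 of the 4 values shown sit.

The compounds shown leave open whether the loss goes with the carboxylic acid at the end of the new group or with any group placed on this oxygen, a question that a plain methyl or the methyl ester of the same chain could separate. They also leave open whether a different ending, such as a short chain carrying an amine, would keep inhibition near the level of compound 1 or lose it in the same way.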